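Swapping a Nitrile for Two Fluorines on Different Cores

This account rests on a few compounds, and the source may have more. Where it says the series, first, only, none or still open, it means among the compounds named here.

The measured compounds:
Compound 1, `N#Cc1cccc(S(=O)(=O)c2cnc3cc(F)ccc3c2-c2cccc(Cl)c2)c1`, gives 0.99 mL/min.
Compound 2, `O=S(=O)(c1ccc(F)c(F)c1)c1cnc2cc(F)ccc2c1-c1cccc(Cl)c1`, gives 0.38 mL/min.
Compound 3, `N#Cc1cccc(S(=O)(=O)c2cnc3c(F)cccc3c2-c2cccc(F)c2)c1`, gives 0.34 mL/min.

All three were tested in an ADME assay on microsomes from liver (Homo sapiens) for metabolic stability, tested at 2.5 uM; on this read-out higher numbers stand for fast clearance and lower numbers for slow clearance. Compound 1 and compound 2 share a core and differ in one place: 3,4-difluorophenyl in place of 3-cyanophenyl on a sulfonyl sulfur. This change gave a 2.6-fold lower number from compound 1 to compound 2 (0.42 log units; beyond the scatter), a step that lies beyond the usual scatter of the measurement.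

Compound 3 has a different core from compound 1; the difference between the two cores is not broken down here. In this assay compound 3 has the lowest of the three numbers, close to compound 2, while compound 1 stands further away.

Compound 4, `O=S(=O)(c1ccc(F)c(F)c1)c1cnc2c(F)cccc2c1-c1cccc(F)c1`, has not yet been measured. It differs from compound 3 in the same way that compound 2 differs from compound 1: 3,4-difluorophenyl in place of 3-cyanophenyl on a sulfonyl sulfur. The place of the change is the same in both pairs, so this is the same change carried onto another core.

The expectation for compound 4 rests on compound 3, which gives 0.34 mL/min, and on the step from compound 1 to compound 2, a 2.6-fold lower number from compound 1 to compound 2 (0.42 log units; beyond the scatter). The cores differ, and the step is expected to be somewhat smaller this time. The estimated step is a 1.9-fold lower number from compound 3 to compound 4 (0.28 log units; within the scatter). Compound 4 is therefore expected to give about 0.18 mL/min in this assay. For compound 4 the expected range runs from 0.08 mL/min to 0.4 mL/min.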

Compound 4, intrinsic clearance in a liver preparation (reported as CLH), per the amount of preparation that the assay uses: 1.28 mL/min
Compound 4: the middle estimate sits 7.1-fold (0.85 log units) below what was measured, outside the stated range (above it).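

On the core of compound 3, putting 3,4-difluorophenyl in place of 3-cyanophenyl on the sulfonyl sulfur gave a 3.8-fold higher number from compound 3 to compound 4 (0.58 log units; beyond the scatter) in this assay, whereas the same swap on the core of compound 1 lowered the number. Set side by side, the two results run in opposite directions, and the gap between them is larger than measurement scatter alone would explain: the same change on two cores in this assay, a 2.6-fold lower number (0.42 log units; beyond the scatter) from compound 1 to compound 2 and a 3.8-fold higher number (0.58 log units; beyond the scatter) from compound 3 to compound 4, 9.8-fold (0.99 log units) apart, beyond the scatter of two such steps

So in this series, the effect of this change on clearance cannot simply be carried from one core to another, although these two pairs do not show which part of the difference between the cores reverses the step, nor do they give a rule for predicting the direction on any other core.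

Going by these compounds, it remains open whether a further core would behave like the core of compound 1, like the core of compound 3, or like neither. The compounds shown also leave open how clearance would respond on either core if the sulfonyl sulfur carried a different kind of group, such as an aliphatic amine or a simple methyl group, instead of either substituted phenyl ring.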